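The source may hold more compounds than are shown below. What is called first, only, known or untested is meant among the compounds shown, and "the series" means these compounds.

In a functional assay on HT-29 cells (Homo sapiens) for antiproliferative activity, read by MTT assay, with a stated time of 72 h, tested at 10 uM (a higher number here means more inhibition at the concentration tested (going by the name of the read-out), a lower number less inhibition), three compounds have been measured:

Compound 1 `O=C(Nc1cc(Oc2ccc(Nc3nccc4[nH]cc(-c5ccc(F)cc5)c(=O)c34)cc2F)ccn1)C1CCC1`: 46%
Compound 2 `CC(=O)Nc1cc(Oc2ccc(Nc3nccc4[nH]cc(-c5ccc(F)cc5)c(=O)c34)cc2F)ccn1`: 36.8%
Compound 3 `CC(O)C(=O)Nc1cc(Oc2ccc(Nc3nccc4[nH]cc(-c5ccc(F)cc5)c(=O)c34)cc2F)ccn1`: 47.8%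

Compound 3 holds the highest of the three numbers. Its nearest neighbour is compound 1, which lies within the scatter of it, as a number 1.8 percentage points higher from compound 1 to compound 3 (within the scatter) shows; compound 2 lies furthest away, the gap being a number 11 percentage points higher from compound 2 to compound 3 (beyond the scatter), a modest but real difference.

Compound 4 `CC(C)C(=O)Nc1cc(Oc2ccc(Nc3nccc4[nH]cc(-c5ccc(F)cc5)c(=O)c34)cc2F)ccn1` differs from compound 3 in one place only: methyl in place of hydroxy on a saturated chain carbon bound to a carbonyl carbon and a saturated chain carbon. Among the measured compounds shown here, no measured step covers exactly this exchange. The step that bears on it most is a number 11 percentage points higher from compound 2 to compound 3 (beyond the scatter), where the hydroxy-bearing group entered in place of methyl on the carbonyl carbon; compound 4 now gives up that hydroxy again, though it keeps a branched chain rather than a bare methyl. The other step, a number 9.2 percentage points lower from compound 1 to compound 2 (within the scatter), shows that a bulkier group on the carbonyl carbon and a plain methyl sit within the scatter of each other.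

Compound 4 is therefore expected to fall somewhat below compound 3, by a number 4.8 percentage points lower from compound 3 to compound 4 (within the scatter), a step not clearly beyond the scatter. The estimate for compound 4 in this assay is 43%, with a range from 33% to 53%.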

Compound 4, a percentage reported as inhibition, at one concentration (the size of the read-out at that concentration, not a potency): 83.4%
Compound 4: middle estimate off by 40.4 percentage points, on the low side; the measured number lies above the stated range.
By their numbers in this assay, from the lowest: compounds 2, 1 and 3 (each within the scatter of the next, the first and the last beyond it); then compound 4.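

In this assay the group on the carbonyl carbon proves far more consequential than the first three compounds suggested: exchanging hydroxy for methyl on the saturated chain carbon gives a number 35.6 percentage points higher from compound 3 to compound 4 (beyond the scatter) and removes the hydroxy without any loss. Isopropyl in place of methyl on the carbonyl carbon gives a number 46.6 percentage points higher from compound 2 to compound 4 (beyond the scatter) and isopropyl in place of cyclobutyl on the carbonyl carbon gives a number 37.4 percentage points higher from compound 1 to compound 4 (beyond the scatter) in the same direction.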